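From Oxolanyl Side Chain to Ethylamino in Compound 4

This account rests on a few compounds, and the source may have more. Where it says the series, first, only, none or still open, it means among the compounds named here.

Compound 1 `Cc1ccc(CNc2nc(NCc3ccccc3)c3ccccc3n2)cc1`: 4500 nM
Compound 2 `CNc1nc(NC(C)C)nc2ccccc12`: "not determined" (no result reported)
Compound 3 `CC(C)Nc1nc(NCC2CCCO2)c2ccccc2n1`: 46000 nM

These results come from an ADME assay on J774.A1 cells (Mus musculus) for inhibition, read by MTT assay, with a stated time of 72 h; a higher number here means that more compound is needed for the effect, a lower number that less compound is needed. Among the measured compounds shown here, only two of the three compounds have a number. Compound 3, at 46000 nM, stands highest of the two, and its gap to compound 1, at 4500 nM, lies beyond the usual scatter. Compound 2 offers no number for comparison.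

The next compound to be tested is compound 4 `CCNc1nc(NC(C)C)nc2ccccc12`. It differs from compound 3 by one change: methyl in place of oxolan-2-yl on a saturated chain carbon bound to a nitrogen on an aromatic ring. Methyl takes the place of oxolan-2-yl on a saturated chain carbon bound to a nitrogen on an aromatic ring, so that (oxolan-2-yl)methyl becomes ethyl.

For the measured compounds named here, no measured pair of compounds shows this change on its own, so its effect has not been observed directly. The estimate therefore starts from compound 3 at 46000 nM, the compound that differs from compound 4 by this single change. No shift in either direction beyond the scatter is expected. The expected step is a 1.1-fold higher number from compound 3 to compound 4 (0.04 log units; within the scatter), and this is an estimate with wide uncertainty. For compound 4 the estimated value is 50000 nM, with an expected range from 20000 nM to 120000 nM.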

Compound 4, half-maximal effective concentration: > 30000 nM
Compound 4: no number, only a limit (the forecaster's own chance of this, stated with the estimate: 25%); the middle value does not contradict the limit.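

Compound 4 gives > 30000 nM, which is a limit and not a number, so the step to it from compound 3 cannot be read. The compounds shown leave open how far the change from (oxolan-2-yl)methyl to ethyl moves the result, and whether any single change on the shared core moves it beyond the scatter.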